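A few compounds are considered here, and "the series" means these few. Any claim that something is new, unique, unknown or untested is made for them only; others in the source may bear on it.

In a functional assay on HCT-116 cells (Homo sapiens) for inhibition, read by MTT assay, with a stated time of 72 h (a lower number here means a stronger inhibitor, a higher number a weaker inhibitor), compound 1 (`CNC(=O)CCCCCCCn1nc(-c2cnc3[nH]ccc3c2)c2c(N)ncnc21`) gives 6760 nM and compound 2 (`Nc1nc2cc(-c3nn(CC(=O)NO)c4ncnc(N)c34)ccc2o1`) gives 11400 nM. These two numbers lie within the usual scatter of each other, so they do not rank the two compounds, and both sit in the same broad range. Compound 3 (`CNC(=O)CCCCCCCn1nc(-c2ccc3oc(N)nc3c2)c2c(N)ncnc21`) keeps the core of compound 2 but has 6-(methylcarbamoyl)hexyl in place of hydroxycarbamoyl on a saturated chain carbon bound to an aromatic nitrogen. For the measured compounds named here, no measured pair shows this change alone. The closest guide is compound 1, which carries the same 6-(methylcarbamoyl)hexyl group on a different core and gives 6760 nM. In this assay, no shift beyond the scatter is therefore expected. The estimated step is a 1.6-fold lower number from compound 2 to compound 3 (0.21 log units; within the scatter). For compound 3, the expected value is 7000 nM, with an estimated range of 2500 nM to 20000 nM.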

Compound 3, half-maximal inhibitory concentration: 3150 nM
For compound 3 the middle estimate is 2.2-fold (0.35 log units) above the measured one; the range from low to high includes it.
By their numbers in this assay, from the lowest: compound 3; then compounds 1 and 2 (each within the scatter of the next).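

In this assay, the group on a saturated chain carbon bound to an aromatic nitrogen clearly affects the result: 6-(methylcarbamoyl)hexyl in place of hydroxycarbamoyl gives a 3.6-fold lower number from compound 2 to compound 3 (0.56 log units; beyond the scatter), a modest step beyond the scatter. For the compounds shown here, with that chain held the same, the group on the aromatic carbon also counts, since exchanging the group in compound 1 for the one in compound 3 gives a 2.1-fold lower number from compound 1 to compound 3 (0.33 log units; beyond the scatter), which is also modest. No measurement here explains either step.

The swap changes the chain length and the group at its end together, so the compounds shown cannot say which of the two matters. A hydroxycarbamoyl group or a carboxylic acid at the end of the same chain would separate these two effects, as would a shorter chain ending in methylcarbamoyl.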